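The source may report more compounds than this note shows. Statements on the series, on what has been measured and on what is new or still open speak of the compounds shown alone.

Measured in an ADME assay on MRC5 cells (Homo sapiens) for inhibition, with a stated time of 72 h; a higher number here means that more compound is needed for the effect, a lower number that less compound is needed:
compound 1 `CO[C@H]1CC[C@H](NC(=O)c2n[nH]cc2NC(=O)c2c(C)nc3ccccn23)CC1`: 34000 nM
compound 2 `COc1cccc(OC)c1C(=O)Nc1c[nH]nc1C(=O)N[C@H]1CC[C@H](OC)CC1`: 31000 nM
compound 3 `CO[C@H]1CC[C@H](NC(=O)c2n[nH]cc2NC(=O)c2cnc3ccccn23)CC1`: 5900 nM

Compound 2 stands second highest of the three numbers in this assay. Its nearest neighbour is compound 1, whose value lies within the scatter of that of compound 2, so no order between these two can be read. Going by the values given here, the only compound set apart is compound 3, whose number is lower than that of compound 2 by more than the scatter.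

Among the compounds with values here, the one step measured, a 5.8-fold lower number from compound 1 to compound 3 (0.76 log units; beyond the scatter), concerns the shared core and not the group on the amide-type nitrogen. It therefore tells nothing about the change to compound 4 `COc1cccc(OC)c1C(=O)Nc1c[nH]nc1C(=O)NCCCOC(C)C`, which is 3-isopropoxypropyl in place of 4-methoxycyclohexyl on an amide-type nitrogen. Within the data shown here, no measured pair shows the effect of exchanging the ring-bearing group on that nitrogen for an open chain, and the data give no step that bears on this change.

Among the measured compounds shown here, with no step to lean on, the expectation for compound 4 in this assay is that the number stays close to that of compound 2, with no step beyond the scatter: no change at the digits printed from compound 2 to compound 4 (within the scatter). Compound 4 is therefore estimated at 31000 nM, with a range from 10000 nM to 95000 nM.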

Compound 4, half-maximal effective concentration: > 50000 nM
Compound 4: no number, only a limit; the forecaster's own chance of this, stated with the estimate: 25%; middle value at least 1.6-fold (0.20 log units) from the limit.
By their numbers in this assay, from the lowest: compound 3; then compounds 2 and 1 (each within the scatter of the next). At a limit, above all of these: compound 4.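

In this assay compound 4 gives > 50000 nM, which is a limit of the assay and not a number. Going by these compounds alone, this is the first measured change on the amide-type nitrogen, with 3-isopropoxypropyl in place of 4-methoxycyclohexyl, and it reads as an at least 1.6-fold higher number from compound 2 to compound 4 (0.20 log units; that floor lies within the scatter). The open chain, with no ring and no defined stereocentres, thus gives no lower number at this position, while the size of any rise cannot be read, and the printed floor remains within the scatter, so the step rests on a limit only: the limit of > 50000 nM in this assay, at which 1 of the 4 values shown sits.

Still open, on these data alone, is whether a true value for compound 4 would lie beyond the scatter from compound 2, and whether a longer chain, or an amine or a carboxylic acid at the end of the chain, would move the number in either direction at this nitrogen. Within the data shown here, also open is whether the same exchange would read alike on the shared core of compound 3, which has the lowest number so far, as no pair on that core carries this change.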